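A few compounds are considered here, and "the series" means these few. Any claim that something is new, unique, unknown or untested is made for them only; others in the source may bear on it.

Measured so far:
compound 1, `CCOC(=O)c1ccc(NC(=O)N2CC2C#N)cc1`: 3000 nM
compound 2, `CC(=O)c1cccc(NC(=O)N2CC2C#N)c1`: 9600 nM
compound 3, `CCOC(=O)CNC(=O)N1CC1C#N`: 30000 nM

In a functional assay on RPMI-8226 cells (Homo sapiens) for inhibition (a lower number here means a stronger inhibitor, a higher number a weaker inhibitor), compound 1 stands lowest of the three numbers. Compound 2 lies nearest, with a number beyond the scatter above it, and compound 3, which carries no aromatic ring, lies furthest, beyond the scatter. The two aryl ureas thus sit well below the open-chain analogue, though with three compounds this is an observation, not a pattern.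

Compound 4, `N#CC1CN1C(=O)Nc1ccc(F)cc1`, is not yet measured in this assay. Against compound 1 it differs in one place: fluoro in place of ethoxycarbonyl on an aromatic carbon. Within the data shown here, no measured pair shows this exchange, so the size of its effect is unknown. The step from compound 1 to compound 4 is expected to raise the number beyond the scatter, since the aromatic urea that compounds 1 and 2 share is kept while the ethoxycarbonyl is lost; the estimated step is a 2.3-fold higher number from compound 1 to compound 4 (0.37 log units; beyond the scatter). Compound 4 is therefore expected to give about 7000 nM, within the range 2500 nM to 20000 nM.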

Compound 4, half-maximal inhibitory concentration: 5900 nM
Compound 4: middle estimate off by 1.2-fold (0.07 log units), on the high side, and the stated range covers the measured number.
By their numbers in this assay, from the lowest: compounds 1, 4 and 2 (each within the scatter of the next, the first and the last beyond it); then compound 3.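

In this assay, the exchange of ethoxycarbonyl for fluoro on an aromatic carbon, para to a group of 8 heavy atoms, gives a 2.0-fold higher number from compound 1 to compound 4 (0.29 log units; within the scatter) and so stays inside the noise of the read-out. At this position, a group of 5 heavy atoms with 2 hydrogen-bond acceptors can thus give way to a single fluorine atom with none, and the ethoxycarbonyl is not shown to be required for the activity of compound 1. No data at hand explain this result.

Open, on these data alone, is whether a carboxylic acid, an amine or a plain hydrogen at this position would also leave the number unchanged. Equally open, as far as these compounds go, is whether a longer ester chain here would separate from compound 1 by more than the scatter.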